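This account rests on a few compounds, and the source may have more. Where it says the series, first, only, none or still open, it means among the compounds named here.

Compound 1 `O=C(OC1CCC(CN2CCN(c3cc(=O)c4cc(C(F)(F)F)cc([N+](=O)[O-])c4s3)CC2)CC1)c1ccccc1` gives > 64 ug/mL
Compound 2 `O=c1cc(N2CCN(CC3CCC(OS(=O)(=O)c4cccnc4)CC3)CC2)sc2c([N+](=O)[O-])cc(C(F)(F)F)cc12` gives > 64 ug/mL

In an ADME assay on Vero cells (Chlorocebus sabaeus) for cytotoxicity, read by MTT assay, with a stated time of 48 h (on this read-out higher numbers stand for weaker inhibition and lower numbers for stronger inhibition), compound 2 gives > 64 ug/mL and this is a limit of the assay, not a number. Compound 1 gives > 64 ug/mL and this too is only a limit. So compound 2 has no readable position, and all that can be said of the pair is the limit of > 64 ug/mL in this assay, at which 2 of the 2 values shown sit, and nothing finer.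

Compound 3 `Cc1cccc(C(=O)OC2CCC(CN3CCN(c4cc(=O)c5cc(C(F)(F)F)cc([N+](=O)[O-])c5s4)CC3)CC2)c1` follows from compound 2 through one change: (3-methylphenyl)carbonyl in place of (pyridin-3-yl)sulfonyl on an oxygen on a saturated carbon is the whole difference. Among the compounds with values here, the only measured step that bears on it is a step that the two limits leave unreadable from compound 1 to compound 2 and it offers no size to carry forward. It does show that benzoyl and (pyridin-3-yl)sulfonyl on that oxygen both leave the read-out at the limit. No step beyond the scatter is therefore expected in this assay and no direction can be assigned. The expected change is a step that the limit leaves unreadable from compound 2 to compound 3 in this estimate. For compound 3 the estimated value is 90 ug/mL with an expected range of 45 ug/mL to 180 ug/mL and a report at the limit is the likeliest outcome.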

Compound 3, half-maximal inhibitory concentration: > 64 ug/mL
Compound 3: a limit, no number; the forecaster's own chance of this, stated with the estimate: 85%; the middle value does not contradict the limit.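

In this assay compound 3 gives > 64 ug/mL, which is a limit of the assay and not a number. No new step can be read among compound 1, compound 2 and compound 3: the limit of > 64 ug/mL in this assay, at which 3 of the 3 values shown sit.

The compounds shown leave open whether the groups on that oxygen differ at all in this read-out.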